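The compounds below may be only part of what the source reports. "The series", "measured", "known", "first", "only" and "open" are said of these compounds alone.

Of the compounds shown here, three have been tested in an ADME assay on MDBK cells (Bos taurus) for cytotoxicity, read by MTT assay, with a stated time of 96 h (on this read-out lower numbers stand for higher toxicity in this test and higher numbers for lower toxicity in this test), and none of them returns a number. Compound 1 (`Cc1ccc(/N=N/N(C)c2ccccc2)cc1`) reads > 100000 nM, which is a limit of the assay. Compound 2 (`Cc1ccc(/N=N/c2ccc(NCCCN(C)C)cc2)cc1`) reads > 100000 nM, again a limit. Compound 3 (`c1ccc(/N=N/N2CCN(c3ccccc3)CC2)cc1`) reads > 100000 nM, also a limit and not a measured number. Compound 3 thus stands with the other two at one shared mark, (the limit of > 100000 nM in this assay, at which 3 of the 3 values shown sit).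

Compound 4 (`c1ccc(/N=N/N2CCN(c3ncccn3)CC2)cc1`) differs from compound 3 in one place, with pyrimidin-2-yl in place of phenyl on an amine nitrogen in a ring. Among the compounds with values here, no pair of measured compounds differs in one place, so no measured step speaks directly to this change. Compound 3 gives only the limit > 100000 nM, and from that starting point no step beyond the scatter is expected in this assay. The expected change is a number no higher from compound 3 to compound 4 (the limit leaves the size open). Compound 4 is estimated at 100000 nM, with an expected range from 40000 nM to 150000 nM.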

Compound 4, half-maximal cytotoxic concentration: > 100000 nM
Compound 4: only a limit was reported; the forecaster's own chance of this, stated with the estimate: 80%; the middle value lies on the limit itself.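

Compound 3 and compound 4 each give only a limit in this assay, so no step can be read between them: the limit of > 100000 nM in this assay, at which 4 of the 4 values shown sit.

The compounds shown leave open what number any of them would reach in this assay, and whether pyrimidin-2-yl in place of phenyl changes it.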